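The source may report more compounds than this note shows. Statements on the series, on what has been measured and on what is new or still open speak of the compounds shown alone.

Three members of this series have been measured in a functional assay on SW480 cells (Homo sapiens) for antiproliferative activity, read by MTT assay, with a stated time of 48 h; on this read-out lower numbers stand for stronger inhibition and higher numbers for weaker inhibition. Compound 1 `O=c1cc(-n2cc(-c3ccccc3)nn2)c2cc(Br)ccc2o1` gives 6660 nM, compound 2 `O=c1cc(-n2cc(CSc3ccccc3)nn2)c2cc(Br)ccc2o1` gives 15400 nM, and compound 3 `O=c1cc(-n2cc(COc3ccnc4ccc(Br)cc34)nn2)c2cc(Br)ccc2o1` gives 17000 nM. Compound 2 thus stands second highest of the three, within the scatter of compound 3, while the measured step of a 2.3-fold higher number from compound 1 to compound 2 (0.36 log units; beyond the scatter) lies beyond the scatter. Compound 4 `O=c1cc(-n2cc(COc3ccccc3Br)nn2)c2cc(Br)ccc2o1` differs from compound 2 by 2-bromophenoxy in place of phenylsulfanyl on a saturated chain carbon bound to an aromatic carbon. Among the compounds with values here, no measured step matches this exchange directly; the single measured step concerns a different replacement, and compound 3, whose value in this assay is 17000 nM, sits within the scatter of compound 2. Compound 4 is therefore expected to show no step beyond the scatter in this assay, a 1.0-fold lower number from compound 2 to compound 4 (0.01 log units; within the scatter). The estimated value of compound 4 is 15000 nM, with a range from 7000 nM to 32000 nM.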

Compound 4, half-maximal inhibitory concentration: 20100 nM
Beside the measured number, compound 4's estimate is 1.3-fold (0.13 log units) below it; the measured number falls inside the stated range.
By their numbers in this assay, from the lowest: compound 1; then compounds 2, 3 and 4 (each within the scatter of the next).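

In this assay, the exchange on a saturated chain carbon bound to an aromatic carbon gives a 1.3-fold higher number from compound 2 to compound 4 (0.12 log units; within the scatter). Phenylsulfanyl and 2-bromophenoxy therefore cannot be told apart at this place, although the entering group brings oxygen in place of sulfur and adds a bromine. Nothing available here accounts for this result. From the compounds shown here alone, whether the bromine and the oxygen each leave the number alone, or only appear to together, stays open. So does whether an amine or a carboxylic acid at this carbon would remain within the scatter of compound 2.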